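Swapping a Benzyl Amide for a Tolyl Anilide

The source may report more compounds than this note shows. Statements on the series, on what has been measured and on what is new or still open speak of the compounds shown alone.

Measured compounds:
compound 1 `O=C(NCc1ccccc1)c1csc(-c2c[nH]c3ccccc23)n1`: > 100000 nM
compound 2 `O=C(Nc1ccccc1)c1csc(-c2cn(Cc3ccc(Cl)cc3)c3ccccc23)n1`: 50500 nM
compound 3 `COc1cc(NC(=O)c2csc(-c3c[nH]c4ccc(Br)cc34)n2)cc(OC)c1OC`: > 100000 nM

In a functional assay on MDA-MB-231 cells (Homo sapiens) for cytotoxicity, read by MTT assay, with a stated time of 48 h, in the absence of a further agent (on this read-out lower numbers stand for stronger inhibition and higher numbers for weaker inhibition), compound 1 is recorded only as a limit, > 100000 nM, not as a number. Compound 3 likewise stands at a limit in this assay, > 100000 nM. Two of the three measured compounds therefore sit at the limit of > 100000 nM in this assay, at which 2 of the 3 values shown sit. Among the compounds with values here, compound 2 is the single compound with a number in this assay, giving 50500 nM.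

Compound 4 `Cc1ccc(NC(=O)c2csc(-c3c[nH]c4ccccc34)n2)cc1` differs from compound 1 in one place: 4-methylphenyl in place of benzyl on an amide-type nitrogen. Within the data shown here, no measured pair isolates this change, so the expected step from compound 1 to compound 4 is an at least 1.1-fold lower number from compound 1 to compound 4 (0.04 log units; that floor lies within the scatter), which is not expected to exceed the scatter. Compound 4 is estimated at 90000 nM, with a range from 30000 nM to 300000 nM.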

Compound 4, half-maximal inhibitory concentration: > 100000 nM
Compound 4 was reported as a limit; the forecaster's own chance of this, stated with the estimate: 60%; middle value at least 1.1-fold (0.04 log units) away from the limit.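

Compound 4 is recorded only as a limit, > 100000 nM, in this assay. Compound 1 is also a limit, so no step can be read between compound 1 and compound 4: the limit of > 100000 nM in this assay, at which 3 of the 4 values shown sit.

The compounds shown leave open whether 4-methylphenyl in place of benzyl on an amide-type nitrogen changes the value at all.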